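Aminoquinoline ethers: oxolanylmethyl in place of cyclopropylmethyl

The compounds below may be only part of what the source reports. "The series", "measured", "known", "first", "only" and "open" are said of these compounds alone.

Measured so far in an assay on cells with melanin-concentrating hormone receptor 1 (Homo sapiens) as the target, read by radioligand binding; on this read-out higher numbers stand for weaker inhibition and lower numbers for stronger inhibition:
Compound 1, `Nc1ccc2cccc(OC3CCCCC3)c2n1`, gives 361 nM.
Compound 2, `COCC(C)Oc1cccc2ccc(N)nc12`, gives 606 nM.
Compound 3, `Nc1ccc2cccc(OCC3CC3)c2n1`, gives only a limit, > 2000 nM, and no number.

Compound 3 stands at the limit of this assay, the weakest of the three shown; (the limit of > 2000 nM in this assay, at which 1 of the 3 values shown sits). Both steps into it were losses: an at least 5.5-fold higher number from compound 1 to compound 3 (0.74 log units; beyond the scatter) and an at least 3.3-fold higher number from compound 2 to compound 3 (0.51 log units; beyond the scatter). Compound 4, `Nc1ccc2cccc(OCC3CCCO3)c2n1`, carries oxolan-2-yl in place of cyclopropyl on a saturated chain carbon bound to an oxygen on an aromatic ring. The entering ring is larger than the leaving one and holds an oxygen, as the side chain of compound 2 does. Since both measured steps into compound 3 were at least modest losses, the step away from it is expected to recover part of that. Compound 4 is therefore expected to give about 900 nM, between 300 nM and 3000 nM, which would mean an at least 2.2-fold lower number from compound 3 to compound 4 (0.34 log units; beyond the scatter) as an expectation only.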

Compound 4, half-maximal inhibitory concentration: > 2000 nM
Compound 4: only a limit was reported; the forecaster's own chance of this, stated with the estimate: 30%; middle value at least 2.2-fold (0.34 log units) from the limit.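

In this assay compound 4 gives > 2000 nM, which is a limit and not a number. The change from cyclopropyl to oxolan-2-yl therefore cannot be read, and the result adds to the values held at the ceiling: the limit of > 2000 nM in this assay, at which 2 of the 4 values shown sit. A ring oxygen in the side chain, which compound 2 also carries in its chain, does not by itself close the gap to the better ethers, with an at least 3.3-fold higher number from compound 2 to compound 4 (0.51 log units; beyond the scatter) and an at least 5.5-fold higher number from compound 1 to compound 4 (0.74 log units; beyond the scatter).

On these data alone, it remains open how compound 3 and compound 4 rank against each other. Also open, as far as these compounds go, is whether cyclohexylmethyl or a chain ending in an amine on the same oxygen would give a readable value.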